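Swapping the Ring-Nitrogen Cap: Expected Lipophilicity

This account rests on a few compounds, and the source may have more. Where it says the series, first, only, none or still open, it means among the compounds named here.

Compound 1 `CCc1ccc(N(CC(C)C)S(=O)(=O)c2ccc3c(c2)C(=O)CC(c2c(C)noc2C)O3)cc1` gives 4.42 in a physicochemical assay for lipophilicity, at pH 7.4; on this read-out higher numbers stand for higher lipophilicity and lower numbers for lower lipophilicity.
Compound 2 `CCc1ccc(N(CC(C)C)S(=O)(=O)c2ccc3c(c2)C(=O)CC(C2CCN(C(=O)C4CCCC4)CC2)O3)cc1` gives 5.13.
Compound 3 `CCc1ccc(N(CC(C)C)S(=O)(=O)c2ccc3c(c2)C(=O)CC(C2CCN(C(=O)OC(C)(C)C)CC2)O3)cc1` gives 5.1.

Compound 3 stands second highest of these three numbers. Its nearest neighbour is compound 2, and the step of a number 0.03 log units lower from compound 2 to compound 3 (within the scatter) lies within the scatter, so the two cannot be told apart; compound 1 sits clearly lower. Compound 4 `CCc1ccc(N(CC(C)C)S(=O)(=O)c2ccc3c(c2)C(=O)CC(C2CCN(S(C)(=O)=O)CC2)O3)cc1` differs from compound 3 in one place: methylsulfonyl in place of tert-butoxycarbonyl on an amine nitrogen in a ring. Among the compounds with values here, no measured step covers this change; the one step seen, tert-butoxy in place of cyclopentyl on a carbonyl carbon, moved nothing beyond the scatter. The entering group is smaller, 4 heavy atoms against 7, with 1 carbon instead of 5. For compound 4 a drop of about a number 1.10 log units lower from compound 3 to compound 4 (beyond the scatter) is therefore expected, giving an estimate of 4 with a range from 3.5 to 4.5.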

Compound 4, distribution coefficient: 3.31
Beside the measured number, compound 4's estimate is 0.69 log units above it; measured number below the stated range.
By their numbers in this assay, from the lowest: compound 4; then compound 1; then compounds 3 and 2 (each within the scatter of the next).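

Unlike the swap between the two carbonyl-linked caps, changing the cap on the amine nitrogen to methylsulfonyl gives a large change in this assay: a number 1.79 log units lower from compound 3 to compound 4 (beyond the scatter) and a number 1.82 log units lower from compound 2 to compound 4 (beyond the scatter). The 1-(methylsulfonyl)piperidin-4-yl group also ends up under the 3,5-dimethyl-1,2-oxazol-4-yl group, a number 1.11 log units lower from compound 1 to compound 4 (beyond the scatter). No measurement offered here explains the size of these drops.

Open, going by these compounds, is where an acetyl cap or a free amine at this nitrogen would fall. Also open, on these data alone, is whether a longer chain on the sulfonyl, such as ethylsulfonyl, would keep the number this low.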